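Swapping a Distant Group While the Proton Stays Put

The source may report more compounds than this note shows. Statements on the series, on what has been measured and on what is new or still open speak of the compounds shown alone.

Compound 1, `COc1ccc(F)cc1CNCCCNc1ccnc2cc(Cc3ccc(C#N)cc3)ccc12`, in a physicochemical assay for acid dissociation, gives 9.47.
Compound 2, `COc1cccc(CNCCCNc2ccnc3cc(Cc4cc(C)cc(C)c4)ccc23)c1O`, gives 9.47.
Compound 3, `COc1cccc(CNCCCNc2ccnc3cc(CCC(C)C)ccc23)c1O`, gives 9.47.

All three share one core and one flexible chain carrying a secondary amine, and differ only in the group hanging from the core or in the substituents on the benzyl end. Compound 1 stands level with compound 2 and compound 3; the three values lie within the scatter of one another. For the measured compounds named here, the single one-place step among them, no change at the digits printed from compound 2 to compound 3 (within the scatter), put an isobutyl in place of a 3,5-dimethylphenyl on a saturated chain carbon bound to an aromatic carbon and left the acid dissociation constant unchanged within the scatter.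

Compound 4, `COc1ccc(F)cc1CNCCCNc1ccnc2cc(Oc3cccc(N(C)C)c3)ccc12`, has not been measured. 3-(dimethylamino)phenoxy in place of 4-cyanobenzyl on an aromatic carbon The leaving and entering groups both sit on an aromatic carbon of the core, remote from the chain carrying the proton whose dissociation is followed. That measured step bears on this one because no change at the digits printed from compound 2 to compound 3 (within the scatter) also altered only the group on the core. No step beyond the scatter is therefore expected. Compound 4 is expected to give 9.47, with a range from 9.15 to 9.8. The expected step is no change at the digits printed from compound 1 to compound 4 (within the scatter), within the scatter.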

Compound 4, acid dissociation constant: 9.28
Compound 4: middle estimate off by 0.19 log units, on the high side; the measured number falls inside the stated range.
By their numbers in this assay, from the lowest: compounds 4, 1, 2 and 3 (each within the scatter of the next).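

In this assay, the new step reads a number 0.19 log units lower from compound 1 to compound 4 (within the scatter), and it exchanges 4-cyanobenzyl for 3-(dimethylamino)phenoxy on the same aromatic carbon of the shared core. The earlier step, no change at the digits printed from compound 2 to compound 3 (within the scatter), replaced one group attached through carbon with another, whereas this one puts a phenoxy group, attached through oxygen, at this position, removes the nitrile and brings in a dimethylamino group. Even this broader exchange stays within the scatter, so two quite different swaps at this position, made in two different compounds, now leave the reading within the scatter, although nothing available explains this result.

The compounds shown leave open whether a group of another kind at this position, such as a carboxylic acid or a primary amine, would also stay within the scatter. They also do not show what a one-place change closer to the secondary amine would do, for example a longer chain between the two nitrogens of the linker, since every step here lies on the core.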